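From piperidin-1-yl to 4-methylpiperazin-1-yl in compound 3

This account rests on a few compounds, and the source may have more. Where it says the series, first, only, none or still open, it means among the compounds named here.

In a functional assay on MDA-MB-231 cells (Homo sapiens) for inhibition, read by MTT assay, with stated times of 18 h and 4 h (on this read-out higher numbers stand for weaker inhibition and lower numbers for stronger inhibition), compound 2 `CCCCCCOP(=O)(O)OCCSC(=S)N1CCCCC1` gives 85000 nM, and compound 1 `CCCCCCCCOP(=O)(O)OCCSC(=S)N1CCN(C)CC1` gives 58500 nM. Going by the values given here, these two values lie within the usual scatter of each other, so compound 2 stands level with compound 1 on the only numbers available.

Compound 3 `CCCCCCOP(=O)(O)OCCSC(=S)N1CCN(C)CC1` is still unmeasured. Relative to compound 2, it carries 4-methylpiperazin-1-yl in place of piperidin-1-yl on a thiocarbonyl carbon. Among the compounds with values here, no measured pair isolates this change, so the expectation rests on little. Compound 1 already carries 4-methylpiperazin-1-yl and gives 58500 nM, within the scatter of compound 2.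

The expected 1.1-fold lower number from compound 2 to compound 3 (0.03 log units; within the scatter) in this assay is therefore none beyond the scatter, with no direction favoured. For compound 3 the estimated value is 80000 nM, with an expected range from 40000 nM to 160000 nM.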

Compound 3, half-maximal inhibitory concentration: 73000 nM
Estimate against measurement, compound 3: 1.1-fold (0.04 log units) above; the measured number falls inside the stated range.
By their numbers in this assay, from the lowest: compounds 1, 3 and 2 (each within the scatter of the next).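

In this assay, 4-methylpiperazin-1-yl in place of piperidin-1-yl on the thiocarbonyl carbon now has a matched pair, which gives a 1.2-fold lower number from compound 2 to compound 3 (0.07 log units; within the scatter) and so shows no separation between these two groups at this position on the shared core. Going by these compounds alone, the same compound gives the first matched reading on the chain, where hydrogen in place of ethyl on a saturated chain carbon gives a 1.2-fold higher number from compound 1 to compound 3 (0.10 log units; within the scatter) and so also shows no separation, leaving neither single change with a measurable effect in these three compounds. No available evidence bears on this result.

As far as these compounds go, whether morpholin-4-yl or a primary amine on the thiocarbonyl carbon would give a step beyond the scatter remains open. From the compounds shown here alone, it also remains open whether a chain longer than those in compound 1 and compound 3, or one ending in a carboxylic acid, would do so.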